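Swapping nitro for bromo in compound 1

The source may hold more compounds than are shown below. What is called first, only, known or untested is meant among the compounds shown, and "the series" means these compounds.

Results in a functional assay on K562 cells (Homo sapiens) for cytotoxicity, read by MTT assay, with a stated time of 72 h (on this read-out lower numbers stand for stronger inhibition and higher numbers for weaker inhibition), so far:
- compound 1 `CC(CC[C@H]1/C(=C/c2ccc([N+](=O)[O-])cc2)CC[C@H]2C(C)(C)CCC[C@]12C)CC(=O)O` gives 169000 nM as a number
- compound 2 `COc1ccc(/C=C2\CC[C@H]3C(C)(C)CCC[C@]3(C)[C@H]2CCC(C)CC(=O)O)cc1OC` gives > 200000 nM as a limit
- compound 3 `CC(CC[C@H]1/C(=C/c2ccc(F)cc2)CC[C@H]2C(C)(C)CCC[C@]12C)CC(=O)O` gives > 200000 nM as a limit

Among the compounds with values here, compound 1 holds the only real number in this small set. The other results make up the limit of > 200000 nM in this assay, at which 2 of the 3 values shown sit, and give no number of their own.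

Compound 4 `CC(CC[C@H]1/C(=C/c2ccc(Br)cc2)CC[C@H]2C(C)(C)CCC[C@]12C)CC(=O)O` has not been measured yet. It carries bromo in place of nitro on an aromatic carbon, para to a large group, which is the change from 4-nitrophenyl to 4-bromophenyl, counted in full as bromo in place of nitro on an aromatic carbon here.

Within the data shown here, two measured steps bear on this change. The closer one is fluoro in place of nitro on an aromatic carbon, which gives an at least 1.1-fold higher number from compound 1 to compound 3 (0.07 log units; that floor lies within the scatter) and ends at a limit. The change to 3,4-dimethoxyphenyl gives an at least 1.1-fold higher number from compound 1 to compound 2 (0.07 log units; that floor lies within the scatter) and also ends at a limit. Neither step can be read as more than scatter, so both are weak guides.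

In this assay no step beyond the scatter is therefore expected, and the estimated step is a 1.1-fold higher number from compound 1 to compound 4 (0.03 log units; within the scatter) in size. The reading may also come back as a limit only. For compound 4 the estimate is 180000 nM (expected range 90000 nM to 350000 nM).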

Compound 4, half-maximal inhibitory concentration: > 200000 nM
Compound 4 was reported as a limit (the forecaster's own chance of this, stated with the estimate: 55%); middle value at least 1.1-fold (0.04 log units) from the limit.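

In this assay, compound 4 returns a limit and not a number, so bromo on this aromatic carbon, para to a large group, gives no more readable a result than fluoro did in compound 3. Going from nitro to bromo gives an at least 1.1-fold higher number from compound 1 to compound 4 (0.07 log units; that floor lies within the scatter), so a second halogen in this place also shows no step beyond the scatter, and only a floor for the step is known. Compound 1 remains the only compound with a real number, and the steps among compound 2, compound 3 and compound 4 cannot be read, as all three sit at the same limit: the limit of > 200000 nM in this assay, at which 3 of the 4 values shown sit.

Going by these compounds, how far compound 4 really lies from compound 1 stays open, as does whether any group on this aromatic carbon, such as an amine or a nitrile in place of nitro, would give a clearly lower number. Also open, on these data alone, is whether a change elsewhere on the shared core, such as an amide in place of the carboxylic acid, would bring these compounds into a range where differences can be measured.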